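A few compounds are considered here, and "the series" means these few. Any claim that something is new, unique, unknown or untested is made for them only; others in the source may bear on it.

Working notes on the series around the shared core of compound 2 `O=C1C=C(Nc2cccc(Cl)c2)C(=O)c2c1nc1n2[C@H]2OC[C@@H](O)[C@H]2OC1`. In a functional assay on HeLa cells (Homo sapiens) for inhibition, read by sulforhodamine B assay (on this read-out lower numbers stand for stronger inhibition and higher numbers for weaker inhibition), compound 2 gives 6040 nM. Compound 1 `Cc1ccc(NC2=CC(=O)c3c(nc4n3[C@H]3OC[C@@H](O)[C@H]3OC4)C2=O)cc1C` carries (3,4-dimethylphenyl)amino where compound 2 carries (3-chlorophenyl)amino; in this assay compound 1 gives 4320 nM. The two numbers sit within the usual scatter of each other, so no order between compound 1 and compound 2 can be read from them. Compound 3 `O=C1C(N2CCCC2)=CC(=O)c2c1nc1n2[C@H]2OC[C@@H](O)[C@H]2OC1` reaches only the limit of this assay, reported as > 16000 nM. Among the compounds with values here, the single measured step, an at least 3.7-fold higher number from compound 1 to compound 3 (0.56 log units; beyond the scatter), rests on that limit (the limit of > 16000 nM in this assay, at which 1 of the 3 values shown sits).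

Compound 4 `O=C1C=C(Nc2cccc(F)c2)C(=O)c2c1nc1n2[C@H]2OC[C@@H](O)[C@H]2OC1` differs from compound 2 by fluoro in place of chloro on an aromatic carbon. Within the data shown here, no measured step exchanges one halogen for another on the aryl ring; the step from compound 1 to compound 3 replaces the whole arylamino group and does not bear on a halogen swap. With nothing in the data pointing either way, the expected step of a 1.0-fold lower number from compound 2 to compound 4 (0.00 log units; within the scatter) is none beyond the scatter. Compound 4 is therefore estimated at 6000 nM in this assay, with a range of 3000 nM to 13000 nM.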

Compound 4, half-maximal inhibitory concentration: 6440 nM
Compound 4: the middle estimate sits 1.1-fold (0.03 log units) below what was measured, and the stated range covers the measured number.
By their numbers in this assay, from the lowest: compounds 1, 2 and 4 (each within the scatter of the next). At a limit, above all of these: compound 3.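

In this assay, fluoro in place of chloro on this aromatic carbon gives a 1.1-fold higher number from compound 2 to compound 4 (0.03 log units; within the scatter), so no difference between the two halogens can be read at this place on the ring. Within the data shown here, the earlier compounds held no exchange of one halogen for another: their only step replaces the whole arylamino group, whereas this one keeps the (3-halophenyl)amino group and exchanges a single atom. Nothing measured on these compounds bears on why chloro and fluoro read alike here.

Still open, going by these compounds, is whether a group other than a halogen on this carbon, such as methoxy, trifluoromethyl or a carboxylic acid, would separate from chloro and fluoro. Also open, on these data alone, is whether fluoro on another carbon of the ring would read the same as compound 4.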